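A few compounds are considered here, and "the series" means these few. Any claim that something is new, unique, unknown or untested is made for them only; others in the source may bear on it.

Measured compounds:
compound 1 `Cc1cccc(N2CCN(CCCNc3nc(NCc4ccco4)c4ccccc4n3)CC2)c1C` — 3310 nM
compound 2 `Cc1cccc(N2CCN(CCCNc3nc(NCc4ccco4)c4cc(F)ccc4n3)CC2)c1C` — "not determined" (no result reported)

For the measured compounds named here, compound 1 is the only compound with a number in a functional assay on MCF7 cells (Homo sapiens) for cytotoxicity, read by MTT assay, with a stated time of 2 days; on this read-out lower numbers stand for stronger inhibition and higher numbers for weaker inhibition; compound 1 gives 3310 nM, and compound 2 has no reported result, so nothing can be set beside it. Compound 3 `Clc1cccc(N2CCN(CCCNc3nc(NCc4ccco4)c4ccccc4n3)CC2)c1Cl` is the untested partner of compound 1, differing by 2,3-dichlorophenyl in place of 2,3-dimethylphenyl on an amine nitrogen in a ring. Going by the values given here, no step between two measured compounds is available to calibrate this exchange, so the expectation rests on compound 1 alone. Since both groups occupy the same position and match in size, the step from compound 1 to compound 3 is expected to stay within the usual scatter, with at most a slight move toward stronger inhibition, as a 1.3-fold lower number from compound 1 to compound 3 (0.12 log units; within the scatter). For compound 3 in this assay the estimate is therefore 2500 nM, with a range from 800 nM to 8000 nM.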

Compound 3, half-maximal inhibitory concentration: 2980 nM
Estimate against measurement, compound 3: 1.2-fold (0.08 log units) below; measured number inside the range.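

In this assay the change at this position now has a measured size: 2,3-dichlorophenyl in place of 2,3-dimethylphenyl on an amine nitrogen in a ring gives a 1.1-fold lower number from compound 1 to compound 3 (0.05 log units; within the scatter), so this read-out does not separate the two groups. For the compounds shown here, the finding covers only this one pair, on the core of compound 1, where the groups entering and leaving match in heavy atoms and in the counts of hydrogen-bond donors and acceptors. No accompanying data bear on this result, so it stays an observation without an explanation.

The compounds shown leave open how this assay would respond to a larger departure on this nitrogen, such as an unsubstituted phenyl, a methoxyphenyl or a pyridine ring. They also leave open whether the same exchange would stay as small with a longer chain in place of the propyl linker.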